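Fluoro in Place of Methoxy on the Shared Core

A few compounds are considered here, and "the series" means these few. Any claim that something is new, unique, unknown or untested is made for them only; others in the source may bear on it.

In a functional assay on T98G cells (Homo sapiens) for inhibition, read by colorimetric assay and MTT assay, with a stated time of 72 h (a lower number here means a stronger inhibitor, a higher number a weaker inhibitor), compound 2 (`COc1ccc2c(c1)-c1cnc(n1C)OCCCCCCCCO2`) gives 68000 nM, level within the scatter with compound 1 (`Cc1ccc2c(c1)-c1cnc(n1C)OCCCCCCCCO2`) at 63000 nM. Compound 3 (`Cn1c2cnc1OCCCCCCCCOc1ccc(F)cc1-2`) carries fluoro in place of methoxy on an aromatic carbon. Within the data shown here, only one measured step bears on this change, methoxy in place of methyl on an aromatic carbon, a 1.1-fold higher number from compound 1 to compound 2 (0.03 log units; within the scatter), and it stayed within the scatter. Among the measured compounds shown here, no fluoro compound has been measured, so no step beyond the scatter is expected in this assay. The expected change is small, a 1.1-fold lower number from compound 2 to compound 3 (0.04 log units; within the scatter). For compound 3 the estimated value is 62000 nM, with an expected range of 30000 nM to 115000 nM.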

Compound 3, half-maximal inhibitory concentration: 77000 nM
For compound 3 the middle estimate is 1.2-fold (0.09 log units) below the measured one, and the stated range covers the measured number.
By their numbers in this assay, from the lowest: compounds 1, 2 and 3 (each within the scatter of the next).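

In this assay, the fluoro compound stands level with both earlier compounds (a 1.1-fold higher number from compound 2 to compound 3 (0.05 log units; within the scatter); a 1.2-fold higher number from compound 1 to compound 3 (0.09 log units; within the scatter)). Among these compounds, with methyl, methoxy and fluoro now compared on this aromatic carbon, all three steps stay within the scatter, whereas the earlier compounds offered only a single step. Nothing shown gives a reason for this. Going by these compounds, it remains open whether an amine or a carboxylic acid on this carbon would give a step beyond the scatter, and whether fluoro would behave the same way on another aromatic carbon of the shared core.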